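The source may hold more compounds than are shown below. What is called first, only, known or untested is meant among the compounds shown, and "the series" means these compounds.

Among the measured compounds shown here, in a functional assay on HT cells (Homo sapiens) for antiproliferative activity, read by fluorescence, with a stated time of 72 h (a higher number here means a weaker inhibitor of growth, a lower number a stronger inhibitor of growth), compound 3 (`CSCCSc1nc(NCc2ccc(-c3ccccn3)cc2)c2[nH]nc(C(C)C)c2n1`) gives 975 nM, the highest number of the three measured so far, against compound 2 (`CC(C)c1n[nH]c2c(NCc3ccc(-c4ccccn4)cc3)nc(SCCNC(N)=O)nc12`) at 240 nM and compound 1 (`CC(C)c1n[nH]c2c(NCc3ccc(-c4ccccn4)cc3)nc(SCCCO)nc12`) at 109 nM. Compound 4 (`CC(C)c1n[nH]c2c(NCc3ccc(-c4ccccn4)cc3)nc(SCCCN)nc12`) carries aminomethyl in place of methylsulfanyl on a saturated chain carbon, two bonds along the chain from a sulfur. For the measured compounds named here, three measured steps concern that same carbon. Methylsulfanyl gave the highest number in both of its comparisons, with an 8.9-fold higher number from compound 1 to compound 3 (0.95 log units; beyond the scatter) and a 4.1-fold higher number from compound 2 to compound 3 (0.61 log units; beyond the scatter), while the two other groups lay closer together, with a 2.2-fold higher number from compound 1 to compound 2 (0.34 log units; beyond the scatter). A similar drop is therefore expected, and the estimate is a 5.7-fold lower number from compound 3 to compound 4 (0.76 log units; beyond the scatter). For compound 4 the expected value is 170 nM, within an estimated range of 60 nM to 500 nM.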

Compound 4, concentration for 50% growth inhibition: 120 nM
Beside the measured number, compound 4's estimate is 1.4-fold (0.15 log units) above it; low and high end bracket the measured number.
By their numbers in this assay, from the lowest: compounds 1, 4 and 2 (each within the scatter of the next, the first and the last beyond it); then compound 3.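

In this assay, a (3-aminopropyl)sulfanyl chain sits far from the (2-(methylsulfanyl)ethyl)sulfanyl chain (an 8.1-fold lower number from compound 3 to compound 4 (0.91 log units; beyond the scatter)). Amino and hydroxy at the chain end cannot be told apart here (a 1.1-fold higher number from compound 1 to compound 4 (0.04 log units; within the scatter)), and neither can the chains of the amine and the urea (a 2.0-fold lower number from compound 2 to compound 4 (0.30 log units; within the scatter)). Among these four compounds, the methylsulfanyl chain alone stands clear of all the others, though compound 1 and compound 2 also remain apart. Nothing shown gives a reason for this result. As far as these compounds go, whether a carboxylic acid at the chain end, or a longer chain carrying the amine, would match compound 4 stays open.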